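From 2,4-dichlorophenyl to phenyl

The compounds below may be only part of what the source reports. "The series", "measured", "known", "first", "only" and "open" are said of these compounds alone.

In a functional assay on SMMC-7721 cells (Homo sapiens) for cytotoxicity, read by MTT assay, with a stated time of 72 h (a lower number here means a stronger inhibitor, a higher number a weaker inhibitor), compound 3 `O=C1C(=Cc2ccc(Cl)cc2Cl)C(=O)N(c2ccc(Cl)cc2)N1c1ccc(Cl)cc1` gives only a limit, > 128000 nM. Compound 1 `O=C1C(=Cc2ccc(O)cc2)C(=O)N(c2ccc(Cl)cc2)N1c1ccc(Cl)cc1` gives 20600 nM, and compound 2 `O=C1C(=Cc2cccc(Cl)c2)C(=O)N(c2ccc(Cl)cc2)N1c1ccc(Cl)cc1` gives 20200 nM. These two show a 1.0-fold lower number from compound 1 to compound 2 (0.01 log units; within the scatter). Compound 4 `O=C1C(=Cc2ccccc2)C(=O)N(c2ccc(Cl)cc2)N1c1ccc(Cl)cc1` differs from compound 3 as follows: phenyl in place of 2,4-dichlorophenyl on a double-bonded chain carbon bound to a double-bonded ring carbon. For the measured compounds named here, the steps that bear on this are an at least 6.2-fold higher number from compound 1 to compound 3 (0.79 log units; beyond the scatter) and an at least 6.3-fold higher number from compound 2 to compound 3 (0.80 log units; beyond the scatter). Both end at the 2,4-dichlorophenyl group, which compound 4 loses, so a return towards the level of compound 1 and compound 2 is expected in this assay. The expected step is an at least 4.2-fold lower number from compound 3 to compound 4 (0.63 log units; beyond the scatter). The estimate for compound 4 is 30000 nM, within an expected range of 12000 nM to 90000 nM.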

Compound 4, half-maximal inhibitory concentration: 26200 nM
Compound 4: middle estimate off by 1.1-fold (0.06 log units), on the high side; the measured number falls inside the stated range.
By their numbers in this assay, from the lowest: compounds 2, 1 and 4 (each within the scatter of the next). At a limit, above all of these: compound 3.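

Taking both chlorines off the 2,4-dichlorophenyl group in this assay returns the series to its common level, with an at least 4.8-fold lower number from compound 3 to compound 4 (0.68 log units; beyond the scatter). Compound 3 stands only at a limit: the limit of > 128000 nM in this assay, at which 1 of the 4 values shown sits. The plain phenyl group does not separate from either substituted ring, with a 1.3-fold higher number from compound 2 to compound 4 (0.11 log units; within the scatter) and a 1.3-fold higher number from compound 1 to compound 4 (0.10 log units; within the scatter), so of the four groups at this place only 2,4-dichlorophenyl departs from that level.

Open, on these data alone, is whether the loss needs both chlorines, which 2-chlorophenyl and 4-chlorophenyl groups would test. Also open, as far as these compounds go, is whether a dimethylamino or carboxylic acid group here would move the number away from that level.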